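Amide variation on the shared hexafluoro-carbinol naphthalene core

A few compounds are considered here, and "the series" means these few. Any claim that something is new, unique, unknown or untested is made for them only; others in the source may bear on it.

Measured compounds:
compound 1 `C/C=C/C(=O)Nc1c(C(O)(C(F)(F)F)C(F)(F)F)ccc2ccccc12` gives 72 nM
compound 2 `CC(C)CCC(=O)Nc1c(C(O)(C(F)(F)F)C(F)(F)F)ccc2ccccc12` gives 49 nM
compound 3 `O=C(Nc1c(C(O)(C(F)(F)F)C(F)(F)F)ccc2ccccc12)c1cccc([N+](=O)[O-])c1` gives 117 nM

All three share the same core and differ only in the group on the amide carbonyl carbon. In an assay on LtK cells with ATP-sensitive inward rectifier potassium channel 11 (Homo sapiens) as the target (on this read-out higher numbers stand for an effect only at larger amounts of compound and lower numbers for an effect already at smaller amounts), compound 3 shows the highest number of the three. Its nearest neighbour is compound 1, where the step of a 1.6-fold higher number from compound 1 to compound 3 (0.21 log units; within the scatter) stays within the scatter; the step of a 2.4-fold higher number from compound 2 to compound 3 (0.38 log units; beyond the scatter) lies beyond the scatter, though only modestly so.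

The next compound, compound 4 `Cc1ccc(C(=O)Nc2c(C(O)(C(F)(F)F)C(F)(F)F)ccc3ccccc23)cc1`, has not yet been measured in this assay. Its change from compound 3 is 4-methylphenyl in place of 3-nitrophenyl on a carbonyl carbon. Going by the values given here, none of the measured steps swaps one aromatic group for another, so no direct precedent exists. The two steps that bear on it, from prop-1-en-1-yl or isopentyl to 3-nitrophenyl, moved the number only modestly or not at all, which suggests that aromatic amides in this series stay in the same broad range. A small drift toward the lower numbers of the aliphatic amides is plausible but not certain; a step of about a 1.3-fold lower number from compound 3 to compound 4 (0.11 log units; within the scatter) is expected, likely within the scatter. Compound 4 is therefore estimated at 90 nM, with a range from 40 nM to 200 nM.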

Compound 4, half-maximal effective concentration: 76 nM
Compound 4: the middle estimate sits 1.2-fold (0.07 log units) above what was measured; the measured number falls inside the stated range.
By their numbers in this assay, from the lowest: compounds 2, 1, 4 and 3 (each within the scatter of the next, the first and the last beyond it).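

In this assay, replacing one aromatic group with another on the carbonyl carbon gives a 1.5-fold lower number from compound 3 to compound 4 (0.19 log units; within the scatter), so 4-methylphenyl, which has no hydrogen-bond acceptors, reads within the scatter of 3-nitrophenyl, which has them. Going by these compounds alone, compound 4 also stays within the scatter of both aliphatic amides, with a 1.6-fold higher number from compound 2 to compound 4 (0.19 log units; within the scatter) and a 1.1-fold higher number from compound 1 to compound 4 (0.02 log units; within the scatter), so an aromatic ring at this position does not by itself set a compound apart from the aliphatic amides, and the one step beyond the scatter remains a 2.4-fold higher number from compound 2 to compound 3 (0.38 log units; beyond the scatter). Nothing available explains these steps.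

The 3-nitrophenyl and 4-methylphenyl groups differ in both the substituent and its place on the ring, so the two changes cannot be separated here. From the compounds shown here alone, it also remains open whether the narrow spread of values holds for a carbonyl substituent carrying an amine or a carboxylic acid, or for a chain longer than isopentyl.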